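Replacing the aminocyclohexyl arm with a hydroxypropylamine chain

The source may hold more compounds than are shown below. What is called first, only, known or untested is meant among the compounds shown, and "the series" means these compounds.

Measured compounds in an assay on HeLa cells for inhibition of sphingosine-1-phosphate transporter SPNS2 (Mus musculus), read by LC-MS, tested at 2 uM; on this read-out lower numbers stand for less inhibition and higher numbers for more inhibition at the one concentration tested (going by the name of the read-out):
compound 1 `CCCCCCCCCCc1ccc(-c2noc(CCCN)n2)cc1`: 67%
compound 2 `CCCCCCCCCCc1ccc(-c2noc([C@H]3CCC[C@@H](N)C3)n2)cc1`: 29%
compound 3 `CCCCCCCCCCc1ccc(-c2noc([C@@H]3CCC[C@@H](N)C3)n2)cc1`: 13%

Compound 3 stands lowest of the three numbers in this assay. Its nearest neighbour is compound 2, and the two differ only in configuration as drawn (the fact that compounds 2 and 3 differ only in the configuration as drawn); the step is a number 16 percentage points lower from compound 2 to compound 3 (beyond the scatter). The flexible 3-aminopropyl chain of compound 1 sits well above both ring-bearing compounds: a number 38 percentage points lower from compound 1 to compound 2 (beyond the scatter) and a number 54 percentage points lower from compound 1 to compound 3 (beyond the scatter).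

Compound 4 `CCCCCCCCCCc1ccc(-c2noc(CC(O)CNCC)n2)cc1` is not yet measured. It differs from compound 3 as follows: 3-(ethylamino)-2-hydroxypropyl in place of 3-aminocyclohexyl on an aromatic carbon. The group that enters is again an open chain, which brings the steps from compound 1 to compound 2 and from compound 1 to compound 3 to bear: in both, replacing the open chain by the 3-aminocyclohexyl ring lowered inhibition by a large amount. Going the other way, from the ring back to an open chain, a rise in this assay is therefore expected, though the chain now carries an ethylamino group and a hydroxyl rather than a primary amine, so the full return to the level of compound 1 is uncertain. The estimated step is a number 37 percentage points higher from compound 3 to compound 4 (beyond the scatter). Compound 4 is expected to give about 50%, within 25% to 75%.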

Compound 4, a percentage reported as inhibition, at one concentration (the size of the read-out at that concentration, not a potency): 5%
Compound 4: the middle estimate sits 45 percentage points above what was measured; the measured number lies below the stated range.
By their numbers in this assay, from the lowest: compounds 4 and 3 (each within the scatter of the next); then compound 2; then compound 1.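

In this assay an open chain on this aromatic carbon does not by itself keep inhibition at the level of compound 1, as the 3-(ethylamino)-2-hydroxypropyl chain shows (a number 62 percentage points lower from compound 1 to compound 4 (beyond the scatter)). Set against the 3-aminocyclohexyl ring, the same chain recovers nothing of what the ring lost (a number 8 percentage points lower from compound 3 to compound 4 (within the scatter); a number 24 percentage points lower from compound 2 to compound 4 (beyond the scatter)), so the earlier contrast between the 3-aminopropyl chain and the ring does not extend to open chains in general on the compounds shown. Nothing given on this series accounts for the low value of compound 4, since the one recorded fact concerns only the configuration of the two ring compounds.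

As far as these compounds go, what remains open is whether the loss follows the hydroxyl or the ethyl group on the nitrogen, a question that a 3-(ethylamino)propyl chain and a 3-amino-2-hydroxypropyl chain would separate. Also open, from the compounds shown here alone, is how a longer chain ending in a primary amine, such as 4-aminobutyl, would compare with the 3-aminopropyl chain of compound 1 at this position.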